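Taking the ethoxy group off compound 2

The source may report more compounds than this note shows. Statements on the series, on what has been measured and on what is new or still open speak of the compounds shown alone.

Compound 1 `COc1cc(-n2ncnc2-c2ccc(C)cc2)cc(OC)c1OC` gives 1100 nM
Compound 2 `CCOc1ccc(-c2ncnn2-c2cc(OC)c(OC)c(OC)c2)cc1Cl` gives 10 nM
Compound 3 `CCOc1ccc(-c2ncnn2-c2cc(OC)c(OC)c(OC)c2)cc1` gives 100 nM
Compound 4 `COc1cc(-n2ncnc2-c2cccc(Cl)c2)cc(OC)c1OC` has not yet been measured

In a functional assay on A549 cells (Homo sapiens) for antiproliferative activity, read by MTT assay, with a stated time of 72 h (on this read-out lower numbers stand for stronger inhibition and higher numbers for weaker inhibition), compound 2 gives 10 nM and stands lowest of the three measured numbers. Its nearest neighbour is compound 3, with a 10-fold higher number from compound 2 to compound 3 (1.00 log units; beyond the scatter) for hydrogen in place of chloro. Compound 1 at 1100 nM lies furthest from it.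

Compound 4 differs from compound 2 in one place (hydrogen in place of ethoxy on an aromatic carbon) on an aromatic carbon ortho to a chloro group and para to a large group. The chloro group stays. Among the compounds with values here, no measured pair exchanges ethoxy for hydrogen directly. The closest evidence is an 11-fold lower number from compound 1 to compound 3 (1.04 log units; beyond the scatter) for ethoxy in place of methyl, a step measured without chloro present. Read in reverse, it suggests a higher number once ethoxy leaves. The other step, a 10-fold higher number from compound 2 to compound 3 (1.00 log units; beyond the scatter) concerns the chloro group that compound 4 retains, so it offers no direct measure of this change.

A large rise is therefore expected in this assay and the expected size is a 30-fold higher number from compound 2 to compound 4 (1.48 log units; beyond the scatter) as estimated here. For compound 4 the estimated value is 300 nM with an expected range from 60 nM to 2000 nM in this read-out.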

Compound 4, half-maximal inhibitory concentration: > 10000 nM
Compound 4 was reported as a limit; the forecaster's own chance of this, stated with the estimate: 10%; middle value at least 33-fold (1.52 log units) from the limit.
By their numbers in this assay, from the lowest: compound 2; then compound 3; then compound 1. At a limit, above all of these: compound 4.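

In this assay compound 4 stands as a limit and not as a number: the limit of > 10000 nM in this assay, at which 1 of the 4 values shown sits. Hydrogen in place of ethoxy, on the aromatic carbon ortho to a chloro group and para to a large group, gives an at least 1000-fold higher number from compound 2 to compound 4 (3.00 log units; beyond the scatter), the first measure of losing this group outright and with the chloro group still present, and it shows that the chloro group does not keep the activity once the ethoxy group has gone. The other new step, 3-chlorophenyl in place of 4-methylphenyl, gives an at least 9.0-fold higher number from compound 1 to compound 4 (0.95 log units; beyond the scatter), so the ring carrying a chloro group alone stands on the weak side even of the methyl-bearing compound, the weakest number measured before.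

The compounds shown leave open how much of the ethoxy group this position needs, since nothing lies between hydrogen and ethoxy here: a methoxy group, a hydroxyl group or a longer chain such as propoxy could each place the number somewhere along this wide step. From the compounds shown here alone, they also leave open whether an amine at this position would behave like ethoxy or like hydrogen, and the full size of the step remains unknown behind the limit.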